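Nitro in Place of Hydrogen on a Phenylurea Quinazoline

A few compounds are considered here, and "the series" means these few. Any claim that something is new, unique, unknown or untested is made for them only; others in the source may bear on it.

Compound 1 `COc1ccccc1NC(=O)Nc1cccc(CNc2ncnc3ccccc23)c1` and compound 2 `COc1cc2ncnc(NCc3cccc(NC(=O)Nc4ccccc4)c3)c2cc1OC` share a benzylamino-linked urea motif on a quinazoline core. In a functional assay on A549 cells (Homo sapiens) for antiproliferative activity, read by MTT assay (on this read-out lower numbers stand for stronger inhibition and higher numbers for weaker inhibition), compound 1 gives 30800 nM, and compound 2 gives 17100 nM; the two numbers lie within the scatter of each other, so neither stands apart. Compound 3 `COc1cc2ncnc(NCc3cccc(NC(=O)Nc4ccc([N+](=O)[O-])cc4)c3)c2cc1OC` is compound 2 with one change, (nitro in place of hydrogen on an aromatic carbon). Among the measured compounds shown here, no measured step informs this change, so compound 3 is expected to differ from compound 2 by at most a modest amount, if at all: the step of a 1.3-fold lower number from compound 2 to compound 3 (0.12 log units; within the scatter) is estimated to fall within the scatter. Compound 3 is estimated at 13000 nM, with a range from 4000 nM to 40000 nM.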

Compound 3, half-maximal inhibitory concentration: > 50000 nM
Compound 3 ended at the assay's limit; the forecaster's own chance of this, stated with the estimate: 5%; at least 3.8-fold (0.58 log units) between middle value and limit.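

In this assay the change from phenyl to 4-nitrophenyl, on a carbon para to a large group, gives an at least 2.9-fold higher number from compound 2 to compound 3 (0.46 log units; beyond the scatter), so this position does not tolerate every group, which compounds 1 and 2 could not show. The value of compound 3, > 50000 nM, is a limit of the assay and not a number, so the step has only a minimum size: the limit of > 50000 nM in this assay, at which 1 of the 3 values shown sits.

From the compounds shown here alone, whether an amine or a carboxylic acid at this position would also weaken inhibition remains open. So does whether nitro would have the same effect elsewhere on this ring.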